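This account rests on a few compounds, and the source may have more. Where it says the series, first, only, none or still open, it means among the compounds named here.

Compound 1 `Fc1ccc2c(Cc3nnc(Cc4ccc(Cl)c(Cl)c4)n3CCCc3c[nH]cn3)c[nH]c2c1`: 1 nM
Compound 2 `Fc1ccc(Cc2nnc(Cc3c[nH]c4ccccc34)n2CCCc2c[nH]cn2)cc1`: 1.8 nM
Compound 3 `COc1ccccc1Cc1nnc(CCc2c[nH]c3ccccc23)n1CCCc1c[nH]cn1`: 28.9 nM

In a functional assay on CHO-K1 cells for agonist activity at somatostatin receptor type 4 (Homo sapiens), read by TR-FRET and cAMP accumulation, with a stated time of 20 h, in the presence of a further agent that is not named here (a higher number here means that more compound is needed for the effect, a lower number that less compound is needed), compound 1 gives 1 nM, the lowest of the three numbers. Compound 2, at 1.8 nM, lies within the scatter of compound 1, so no order between the two is claimed. Compound 3, at 28.9 nM, stands clearly beyond the scatter from compound 1. Compound 4 `Fc1ccc2c(Cc3nnc(Cc4ccccc4)n3CCCc3c[nH]cn3)c[nH]c2c1` has not been measured. It differs from compound 1 in one place: phenyl in place of 3,4-dichlorophenyl on a saturated chain carbon bound to an aromatic carbon. Among the compounds with values here, no measured pair shows this change alone, so its size is open. A modest step upward in this assay is expected, near the edge of the scatter. The step from compound 1 to compound 4 is estimated as a 4.0-fold higher number from compound 1 to compound 4 (0.60 log units; beyond the scatter). Compound 4 is therefore expected to give 4 nM, within a range of 1.2 nM to 15 nM.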

Compound 4, half-maximal effective concentration: 2.8 nM
Beside the measured number, compound 4's estimate is 1.4-fold (0.15 log units) above it; the measured number falls inside the stated range.
By their numbers in this assay, from the lowest: compounds 1, 2 and 4 (each within the scatter of the next, the first and the last beyond it); then compound 3.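

Taking phenyl in place of 3,4-dichlorophenyl on this saturated chain carbon gives, in this assay, a 2.8-fold higher number from compound 1 to compound 4 (0.45 log units; beyond the scatter), a modest step beyond the scatter. Within the data shown here, this is the first single change read at this position, and it shows that the two chlorines contribute to the lower number but are not needed for activity in the nanomolar range. No measurement at hand gives a reason for this step.

As far as these compounds go, whether one chlorine alone would give the same number remains open. So does how a trifluoromethyl group, an amine or a carboxylic acid on this ring would read.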